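This account rests on a few compounds, and the source may have more. Where it says the series, first, only, none or still open, it means among the compounds named here.

Measured so far:
compound 1, `O=C(Nc1c(C(O)(C(F)(F)F)C(F)(F)F)ccc2ccccc12)C1CCC1`: 45 nM
compound 2, `O=C(CC1CCCC1)Nc1c(C(O)(C(F)(F)F)C(F)(F)F)ccc2ccccc12`: 81 nM
compound 3, `CC(C)OC(=O)Nc1c(C(O)(C(F)(F)F)C(F)(F)F)ccc2ccccc12`: 1160 nM

The three share one core and differ only in the group on the carbonyl carbon attached to the amide-type nitrogen. In an assay on LtK cells with ATP-sensitive inward rectifier potassium channel 11 (Homo sapiens) as the target (on this read-out lower numbers stand for an effect already at smaller amounts and higher numbers for an effect only at larger amounts of compound), compound 3 gives the highest of the three numbers; the nearest measured compound is reached by a 14-fold higher number from compound 2 to compound 3 (1.16 log units; beyond the scatter) and the furthest by a 26-fold higher number from compound 1 to compound 3 (1.41 log units; beyond the scatter), both beyond the scatter. Compound 1 and compound 2 lie close together, a 1.8-fold higher number from compound 1 to compound 2 (0.26 log units; within the scatter), within the scatter.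

Compound 4 `O=C(Nc1c(C(O)(C(F)(F)F)C(F)(F)F)ccc2ccccc12)c1ccccc1Cl` is not yet measured. Its change from compound 3 reads: 2-chlorophenyl in place of isopropoxy on a carbonyl carbon. This again replaces isopropoxy on the carbonyl carbon, so the two steps into compound 3 bear on it in reverse: a 26-fold higher number from compound 1 to compound 3 (1.41 log units; beyond the scatter) and a 14-fold higher number from compound 2 to compound 3 (1.16 log units; beyond the scatter) were both large. Within the data shown here, no measured compound carries an aromatic ring at this position, so the exact size cannot be fixed from the data, but a large step to a lower number in this assay is expected. Compound 4 is estimated at 70 nM (range 20 nM to 250 nM), which is expected to mean a step of a 17-fold lower number from compound 3 to compound 4 (1.22 log units; beyond the scatter).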

Compound 4, half-maximal effective concentration: 2040 nM
Compound 4: middle estimate off by 29-fold (1.46 log units), on the low side; the whole stated range lies below it.
By their numbers in this assay, from the lowest: compounds 1 and 2 (each within the scatter of the next); then compounds 3 and 4 (each within the scatter of the next).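

In this assay, replacing isopropoxy with 2-chlorophenyl leaves the number in the same place, a 1.8-fold higher number from compound 3 to compound 4 (0.25 log units; within the scatter), so a change from an oxygen-linked open group with one hydrogen-bond acceptor to a carbon-linked aromatic ring with none does not separate these two compounds. Compound 4 stays well apart from both compounds with a saturated carbon ring at this position, a 25-fold higher number from compound 2 to compound 4 (1.40 log units; beyond the scatter) and a 45-fold higher number from compound 1 to compound 4 (1.66 log units; beyond the scatter), so among these four compounds the low numbers occur only with cyclobutyl and cyclopentylmethyl. No measurement here explains this split.

Going by these compounds, whether the ring or its chlorine sets the value of compound 4 remains open, and plain phenyl would separate the two. Also open, on these data alone, is how cyclohexyl, a longer alkyl chain or an amine on the carbonyl carbon would read.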